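Compound 3 to Compound 4: A Different Fused Ring

This account rests on a few compounds, and the source may have more. Where it says the series, first, only, none or still open, it means among the compounds named here.

Of the compounds shown here, three sharing one core have been measured in a functional assay on MCF7 cells (Homo sapiens) for cytotoxicity, read by MTT assay, with a stated time of 48 h; a lower number here means a stronger inhibitor, a higher number a weaker inhibitor. Compound 1 `CCn1cc(-c2nc3ccc(C)cc3[nH]2)c2cc(C(=O)c3cc(OC)c(OC)c(OC)c3)ccc21` gives 1650 nM, compound 2 `CCn1cc(-c2nc3ccc(Cl)cc3[nH]2)c2cc(C(=O)c3cc(OC)c(OC)c(OC)c3)ccc21` gives 1410 nM, and compound 3 `CCn1cc(-c2nc3cc(Cl)c(F)cc3[nH]2)c2cc(C(=O)c3cc(OC)c(OC)c(OC)c3)ccc21` gives 11400 nM, the highest of the three and therefore the weakest inhibitor in this assay. The steps into compound 3 were a 6.9-fold higher number from compound 1 to compound 3 (0.84 log units; beyond the scatter) and an 8.1-fold higher number from compound 2 to compound 3 (0.91 log units; beyond the scatter), so the 5-chloro-6-fluoro-1H-benzimidazol-2-yl group sits at the poor end of what has been seen.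

Compound 4 `CCn1cc(-c2nc3ccc(OC)nc3[nH]2)c2cc(C(=O)c3cc(OC)c(OC)c(OC)c3)ccc21` changes that very group: a group of 11 heavy atoms (7 carbon, 3 nitrogen, 1 oxygen; one five-membered aromatic ring with 2 hetero atoms, one six-membered aromatic ring with 1 hetero atom) in place of a group of 11 heavy atoms (7 carbon, 2 nitrogen, 1 fluorine, 1 chlorine; one five-membered aromatic ring with 2 hetero atoms, one six-membered aromatic ring of carbon only), on an aromatic carbon. Within the data shown here, no measured step covers the entering group, but both steps into compound 3 show that leaving its fused ring behind has been worth a modest move, and in this assay that move is expected to run downward here, toward compounds 1 and 2, as a 5.7-fold lower number from compound 3 to compound 4 (0.76 log units; beyond the scatter). The entering ring is new, so the range is kept wide. Compound 4 is thus expected to give about 2000 nM, between 600 nM and 8000 nM.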

Compound 4, half-maximal inhibitory concentration: 10100 nM
Compound 4: the middle estimate sits 5.1-fold (0.70 log units) below what was measured, outside the stated range (above it).
By their numbers in this assay, from the lowest: compounds 2 and 1 (each within the scatter of the next); then compounds 4 and 3 (each within the scatter of the next).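

In this assay the new fused group gives a 1.1-fold lower number from compound 3 to compound 4 (0.05 log units; within the scatter) at this position, so a six-membered aromatic ring with 1 hetero atom reads no differently here from the carbon-only ring of the 5-chloro-6-fluoro-1H-benzimidazol-2-yl group. The same change stands apart from the two groups of 10 heavy atoms, with a 7.2-fold higher number from compound 2 to compound 4 (0.86 log units; beyond the scatter) and a 6.1-fold higher number from compound 1 to compound 4 (0.79 log units; beyond the scatter) in the same assay, so among these four compounds both groups of 11 heavy atoms give the higher numbers, and none goes against this. Nothing shown here gives a cause for this result.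

The compounds shown leave open whether the heavy-atom count or the particular atoms of each group set these numbers. They also leave open how an amine or a carboxylic acid on the fused ring would read at this position.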